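The compounds below may be only part of what the source reports. "The series", "measured", "known", "first", "only" and "open" are said of these compounds alone.

Measured compounds:
Compound 1 `CNC(=O)O[C@@H]1CO[C@]2(COC(C)(C)O2)[C@@](O)(C2(C)CO2)[C@@H]1OC`: > 500000 nM
Compound 2 `CO[C@@H]1[C@H](OC(=O)NC(=O)CCl)CO[C@]2(COC(=O)O2)[C@]1(CCCCCc1ccccc1)OC(=O)NC(=O)CCl`: 2000 nM

In a functional assay on A-431 cells (Homo sapiens) for antiproliferative activity (on this read-out lower numbers stand for stronger inhibition and higher numbers for weaker inhibition), compound 1 gives only a limit, > 500000 nM, so no number is known for it. Compound 1 therefore sits at the limit of > 500000 nM in this assay, at which 1 of the 2 values shown sits, and its true potency is not resolved by the numbers shown. Compound 2, which carries two ((chloromethyl)carbonyl)carbamoyl groups on a different core, gives 2000 nM in this assay; no one-step comparison links compound 2 to compound 1.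

Compound 3 `CO[C@@H]1[C@H](OC(=O)NC(=O)CCl)CO[C@]2(COC(C)(C)O2)[C@@]1(O)C1(C)CO1` is to be measured in this assay. It differs from compound 1 by (chloromethyl)carbonyl in place of methyl on an amide-type nitrogen.

Since compound 1 stands only at a limit, the step to compound 3 can only be judged against that limit. The expected step is an at least 10-fold lower number from compound 1 to compound 3 (1.00 log units; beyond the scatter), a gain in inhibition beyond the usual scatter. For compound 3 the estimate is 50000 nM, with a range from 5000 nM to 500000 nM.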

Compound 3, half-maximal inhibitory concentration: 84000 nM
Beside the measured number, compound 3's estimate is 1.7-fold (0.23 log units) below it; measured number inside the range.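

In this assay the swap of methyl for (chloromethyl)carbonyl on the amide-type nitrogen gives a compound with a readable number, and the change amounts to an at least 5.9-fold lower number from compound 1 to compound 3 (0.77 log units; beyond the scatter). Compound 1 gives > 500000 nM, which is a limit of the assay and not a number. The size of the step is therefore only a minimum, and it rests entirely on that one limit: the limit of > 500000 nM in this assay, at which 1 of the 3 values shown sits.

The compounds shown leave open whether the chlorine itself matters or whether the added carbonyl alone would produce the same shift, a question that a plain acetyl group on the same nitrogen would address. They also leave open how a bromoacetyl group or a longer chain in this place would compare with (chloromethyl)carbonyl.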